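The source may hold more compounds than are shown below. What is called first, only, known or untested is meant among the compounds shown, and "the series" means these compounds.

Compound 1: `O=C(CCCCCCC(=O)Nc1nnc(-c2cccnc2)s1)NO`, 1870 nM
Compound 2: `O=C(CCCCCC(=O)Nc1nnc(-c2ccncc2)s1)NO`, 40100 nM

In a functional assay on MDA-MB-231 cells (Homo sapiens) for antiproliferative activity, read by MTT assay, with a stated time of 48 h (a lower number here means a stronger inhibitor, a higher number a weaker inhibitor), compound 1 gives 1870 nM, the lower of the two numbers measured, while compound 2 gives 40100 nM, a gap beyond the usual scatter. Compound 3, `O=C(CCCCCC(=O)Nc1nnc(-c2cccnc2)s1)NO`, is not yet measured. It differs from compound 1 in one place: hydroxycarbamoyl in place of (hydroxycarbamoyl)methyl on a saturated chain carbon, five bonds along the chain from a carbonyl carbon. The saturated chain linking the two carbonyl groups is thereby shortened. Among the compounds with values here, no measured pair isolates this change, so its effect cannot be read from the data; a weakening step of moderate size is expected, and the step expected is a 3.2-fold higher number from compound 1 to compound 3 (0.51 log units; beyond the scatter). Compound 3 is estimated at 6000 nM, with a range from 1500 nM to 25000 nM.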

Compound 3, half-maximal inhibitory concentration: 11700 nM
Estimate against measurement, compound 3: 2.0-fold (0.29 log units) below, within the range that was stated.
By their numbers in this assay, from the lowest: compound 1; then compound 3; then compound 2.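

In this assay, putting hydroxycarbamoyl in place of (hydroxycarbamoyl)methyl shortens the saturated chain and gives a 6.3-fold higher number from compound 1 to compound 3 (0.80 log units; beyond the scatter) with pyridin-3-yl held constant, so the longer of these two chains gives the lower number. The same compound completes a second one-place comparison: pyridin-3-yl in place of pyridin-4-yl gives a 3.4-fold lower number from compound 2 to compound 3 (0.53 log units; beyond the scatter) on the shorter chain. Nothing measured here explains either step. Two chain lengths cannot show whether a longer chain would lower the number further. Going by these compounds, how phenyl or pyridin-2-yl would compare with pyridin-3-yl also remains open.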